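Halogen swap on the aryl piperazine of a thiophene core

The source may hold more compounds than are shown below. What is called first, only, known or untested is meant among the compounds shown, and "the series" means these compounds.

Measured compounds:
Compound 1, `Nc1scc(CN2CCN(c3cccc(C(F)(F)F)c3)CC2)c1C(=O)c1ccc(Cl)cc1`: -72%
Compound 2, `Nc1scc(CN2CCN(c3ccc(Cl)c(C(F)(F)F)c3)CC2)c1C(=O)c1ccc(Cl)cc1`: -47%
Compound 3, `Nc1scc(CN2CCN(c3ccncc3)CC2)c1C(=O)c1ccc(Cl)cc1`: -8.3%

The three compounds were tested in a functional assay on CHO cells with adenosine receptor A1 (Homo sapiens) as the target, read by cAMP accumulation and immunoassay, with a stated time of 6 min, tested at 1 uM; a higher number here means a weaker effect of the compound at the concentration tested, a lower number a stronger effect. Compound 1 stands at the lowest number of the three; its nearest neighbour is compound 2, and the step of a number 25 percentage points higher from compound 1 to compound 2 (beyond the scatter) is modest, while the step of a number 63.7 percentage points higher from compound 1 to compound 3 (beyond the scatter) is large. The step of a number 38.7 percentage points higher from compound 2 to compound 3 (beyond the scatter) is large as well, so the aryl group on the ring nitrogen is the place where the numbers move.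

Compound 4, `Nc1scc(CN2CCN(c3ccc(F)c(Cl)c3)CC2)c1C(=O)c1ccc(Cl)cc1`, has not been measured. It differs from compound 1 in one place: 3-chloro-4-fluorophenyl in place of 3-(trifluoromethyl)phenyl on an amine nitrogen in a ring. For the measured compounds named here, of the measured steps, the one from compound 1 to compound 2 bears most closely on this change, since it also keeps a halogenated phenyl ring on the ring nitrogen and raises the number only modestly; the step to compound 3, which exchanges the phenyl for pyridin-4-yl, is a larger departure and less informative here. Compound 4 is therefore expected to lie near compound 1 or somewhat above it, a step of a number 17 percentage points higher from compound 1 to compound 4 (beyond the scatter) that may or may not exceed the scatter. The estimate for compound 4 is -55%, with a range from -80% to -25%.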

Compound 4, a percentage reported as activity, at one concentration (the size of the read-out at that concentration, not a potency): -60%
Beside the measured number, compound 4's estimate is 5 percentage points above it; the measured number falls inside the stated range.
By their numbers in this assay, from the lowest: compound 1; then compound 4; then compound 2; then compound 3.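

In this assay, the new step shows that the trifluoromethyl group is not needed for a low number at this position: with 3-chloro-4-fluorophenyl on the ring nitrogen, the change is only a number 12 percentage points higher from compound 1 to compound 4 (beyond the scatter), whereas the change from the other direction, with this ring replacing pyridin-4-yl, is a number 51.7 percentage points lower from compound 3 to compound 4 (beyond the scatter). It also shows that a chlorine on the phenyl ring does not by itself carry a compound up to the level of compound 2, since the step with 3-chloro-4-fluorophenyl in place of 4-chloro-3-(trifluoromethyl)phenyl is a number 13 percentage points lower from compound 2 to compound 4 (beyond the scatter), so among these rings the number depends on the whole substitution pattern rather than on one halogen. Nothing shown explains why these aryl groups differ in this way.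

The compounds shown leave open where an unsubstituted phenyl, or a phenyl bearing a methoxy group or a single fluorine, would fall among these values, and so which substituent on the ring accounts for the gaps. They also leave open whether the same order would hold as potency, as each read-out comes from a single concentration.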